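Aryl imine series: nitro in place of methoxy

This account rests on a few compounds, and the source may have more. Where it says the series, first, only, none or still open, it means among the compounds named here.

Measured so far in a functional assay on HCT-116 cells (Homo sapiens) for cytotoxicity, read by MTT assay, with a stated time of 72 h; on this read-out higher numbers stand for weaker inhibition and lower numbers for stronger inhibition:
compound 1 `CCOc1cccc(/C=N/c2c(C)n(C)n(-c3ccccc3)c2=O)c1` gives 933000000 nM
compound 2 `Cc1c(/N=C/c2cccc(O)c2)c(=O)n(-c2ccccc2)n1C` gives 617000000 nM
compound 3 `COc1cccc(/C=N/c2c(C)n(C)n(-c3ccccc3)c2=O)c1` gives 933000000 nM

Compound 3 stands level with compound 1 at the digits recorded, and compound 2 sits within the scatter of both. The three measured steps all concern the group on the aromatic oxygen: no change at the digits printed from compound 1 to compound 3 (within the scatter), a 1.5-fold lower number from compound 1 to compound 2 (0.18 log units; within the scatter) and a 1.5-fold higher number from compound 2 to compound 3 (0.18 log units; within the scatter), none of them beyond the scatter. The series shows no movement in this assay across ethyl, methyl and hydrogen on that oxygen.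

Compound 4 `Cc1c(/N=C/c2cccc([N+](=O)[O-])c2)c(=O)n(-c2ccccc2)n1C` replaces the oxygen-bearing group entirely: nitro in place of methoxy on an aromatic carbon. For the measured compounds named here, no measured step touches this change, so nothing among the three compounds argues for movement in either direction; the only evidence is that the whole series sits at very high numbers in this assay with no substituent effect resolved. Compound 4 is therefore expected to stay at the level of compound 3, a 1.0-fold lower number from compound 3 to compound 4 (0.02 log units; within the scatter), with a wide band to allow for the untested group. Estimate for compound 4: 900000000 nM, range 300000000 nM to 2500000000 nM.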

Compound 4, half-maximal inhibitory concentration: 363000000 nM
Estimate against measurement, compound 4: 2.5-fold (0.39 log units) above, and the stated range covers the measured number.
By their numbers in this assay, from the lowest: compounds 4, 2, 1 and 3 (each within the scatter of the next, the first and the last beyond it).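

In this assay, for the compounds shown here, the aromatic carbon carrying the oxygen-bearing group gives the first steps beyond the scatter: nitro in place of methoxy gives a 2.6-fold lower number from compound 3 to compound 4 (0.41 log units; beyond the scatter), and nitro in place of ethoxy gives a 2.6-fold lower number from compound 1 to compound 4 (0.41 log units; beyond the scatter), while changes on the oxygen itself gave none. Nitro in place of hydroxy gives a 1.7-fold lower number from compound 2 to compound 4 (0.23 log units; within the scatter), so compound 4 is not separated from compound 2 and the effect of nitro holds against only two of the three oxygen-bearing groups. Nothing measured here explains the step.

Going by these compounds, it remains open whether an amine, a nitrile or a carboxylic acid on the same aromatic carbon would stay level with compound 3 or go with compound 4. The compounds shown also leave open whether any group at this position can bring the numbers far below this very high range.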